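Nitro for methoxy in the ester series of compound 1

The source may hold more compounds than are shown below. What is called first, only, known or untested is meant among the compounds shown, and "the series" means these compounds.

compound 1 `CCOC(=O)c1cn(-c2cccc(OC)c2)nc1CC(C)C`: 70500 nM
compound 2 `CC(C)Cc1nn(-c2cccc(F)c2)cc1C(=O)NCc1ccccc1`: 85900 nM
compound 3 `CC(C)Cc1nn(-c2nccs2)cc1C(=O)NCc1ccc(F)cc1`: > 100000 nM

The three compounds share a core and were read in a toxicity assay on HepG2 2.2.15 cells (Homo sapiens) for cytotoxicity, read by CCK-8 assay, with a stated time of 8 days; a lower number here means that less compound is tolerated, a higher number that more compound is tolerated. Compound 1 stands lowest of the two numbers in this assay, with compound 2 nearest and within the scatter of it, so no order between them is claimed. Compound 3 gives only a limit in this assay, > 100000 nM, namely (the limit of > 100000 nM in this assay, at which 1 of the 3 values shown sits).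

Compound 4, `CCOC(=O)c1cn(-c2cccc([N+](=O)[O-])c2)nc1CC(C)C`, differs from compound 1 by nitro in place of methoxy on an aromatic carbon. For the measured compounds named here, no measured pair in this set isolates such a change, so the expectation rests on compound 1 alone. The expected step of a 1.2-fold lower number from compound 1 to compound 4 (0.07 log units; within the scatter) is within the scatter, with no direction claimed. Compound 4 is therefore estimated at 60000 nM, between 25000 nM and 100000 nM.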

Compound 4, half-maximal cytotoxic concentration: 59300 nM
Beside the measured number, compound 4's estimate is 1.0-fold (0.01 log units) above it; the measured number falls inside the stated range.
By their numbers in this assay, from the lowest: compounds 4, 1 and 2 (each within the scatter of the next). At a limit, above all of these: compound 3.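

Nitro in place of methoxy on an aromatic carbon, meta to a large group, gives the first pair in the series that differs in one place: a 1.2-fold lower number from compound 1 to compound 4 (0.08 log units; within the scatter) in this assay. In the ester series, this position therefore carries either group with no readable change in the number. Nothing at hand bears on a cause for this step.

The compounds shown leave open whether an amine or a carboxylic acid at this position would stay within the scatter of compound 1. Going by these compounds, the same exchange in the amide series of compound 2 also remains open.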